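Swapping pyrimidin-2-yl for 4-methylphenyl at the assay limit

This account rests on a few compounds, and the source may have more. Where it says the series, first, only, none or still open, it means among the compounds named here.

In an ADME assay on HeLa cells (Homo sapiens) for cytotoxicity, read by ATP content, with a stated time of 3 days (a higher number here means that more compound is tolerated, a lower number that less compound is tolerated), compound 3 (`N#CCCCn1c(Cn2c(=O)n(-c3ncccn3)c3ccncc32)cc2cc(Cl)ccc21`) gives > 50000 nM as a limit of the assay, not as a number. Compound 1 (`Cn1ccc(-n2c(=O)n(Cc3cc4cc(Cl)ccc4n3CCCC#N)c3cnccc32)n1`) gives > 50000 nM as a limit too. Compound 2 (`N#CCCCn1c(Cn2c(=O)n(-c3ncco3)c3ccncc32)cc2cc(Cl)ccc21`) likewise gives > 50000 nM as a limit. All the measured compounds therefore stand at one and the same limit (the limit of > 50000 nM in this assay, at which 3 of the 3 values shown sit).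

Compound 4 (`Cc1ccc(-n2c(=O)n(Cc3cc4cc(Cl)ccc4n3CCCC#N)c3cnccc32)cc1`) carries 4-methylphenyl in place of pyrimidin-2-yl on an aromatic nitrogen. The group that leaves is one six-membered aromatic ring with 2 hetero atoms, and the group that enters is one six-membered aromatic ring of carbon only.

Three measured swaps on this same nitrogen bear on the change (a step that the two limits leave unreadable from compound 1 to compound 2; a step that the two limits leave unreadable from compound 1 to compound 3; a step that the two limits leave unreadable from compound 2 to compound 3). None of them has a readable size, so they give no direction, and none of them brings in a ring of carbon only. The expectation is thus that this assay shows no step beyond the usual scatter, and another limit is the most likely report. The estimated step is small (a number no higher from compound 3 to compound 4 (the limit leaves the size open)). For compound 4 the expected value is 50000 nM with 20000 nM to 80000 nM as the estimated range.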

Compound 4, half-maximal cytotoxic concentration: > 50000 nM
Compound 4 gave a limit, no number; the forecaster's own chance of this, stated with the estimate: 75%; the middle value sits exactly at the limit.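

In this assay compound 4 gives > 50000 nM, which is a limit and not a number, so no step from compound 1, compound 2 or compound 3 to compound 4 can be read: the limit of > 50000 nM in this assay, at which 4 of the 4 values shown sit.

The compounds shown leave open what concentration of any of them reaches the half-maximal cytotoxic level, and whether the group on this aromatic nitrogen matters for it.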